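Aryloxymethyl ketone pair: tetrafluorophenoxy in place of nitrophenoxy

The source may hold more compounds than are shown below. What is called first, only, known or untested is meant among the compounds shown, and "the series" means these compounds.

Compound 1 `CC(C)[C@H](NC(=O)COc1cccc2ccccc12)C(=O)N[C@@H](CC(=O)O)C(=O)COc1ccc(Oc2ccc(C(F)(F)F)cc2)cc1` gives 24900 nM in a functional assay with Homo sapiens as the target; on this read-out higher numbers stand for weaker inhibition and lower numbers for stronger inhibition. Compound 2 `CC(C)[C@H](NC(=O)COc1cccc2ccccc12)C(=O)N[C@@H](CC(=O)O)C(=O)COc1ccc([N+](=O)[O-])cc1` gives 22800 nM in this assay; the step of a 1.1-fold lower number from compound 1 to compound 2 (0.04 log units; within the scatter) lies within the scatter, so the two numbers do not separate and compound 2 stands level with compound 1. Compound 3 `CC(C)[C@H](NC(=O)COc1cccc2ccccc12)C(=O)N[C@@H](CC(=O)O)C(=O)COc1c(F)c(F)cc(F)c1F` differs from compound 2 by 2,3,5,6-tetrafluorophenyl in place of 4-nitrophenyl on an oxygen on a saturated carbon. For the measured compounds named here, the only step bearing on it, the earlier exchange at the same oxygen on a saturated carbon, a 1.1-fold lower number from compound 1 to compound 2 (0.04 log units; within the scatter), stayed within the scatter, so no step beyond the scatter is expected in this assay. Compound 3 is estimated at 21000 nM, with a range of 7000 nM to 60000 nM. The expected step is a 1.1-fold lower number from compound 2 to compound 3 (0.04 log units; within the scatter).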

Compound 3, half-maximal inhibitory concentration: 6250 nM
Compound 3: middle estimate off by 3.4-fold (0.53 log units), on the high side, outside the stated range (below it).
By their numbers in this assay, from the lowest: compound 3; then compounds 2 and 1 (each within the scatter of the next).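

In this assay the exchange at this oxygen on a saturated carbon gives a 3.6-fold lower number from compound 2 to compound 3 (0.56 log units; beyond the scatter) and so separates from the scatter, whereas the earlier exchange at the same oxygen gave a 1.1-fold lower number from compound 1 to compound 2 (0.04 log units; within the scatter) and did not. The read-out at this position therefore responds to the aryl group, at least for 2,3,5,6-tetrafluorophenyl against 4-nitrophenyl. No evidence on hand bears on this step.

Open, going by these compounds, is whether the fluorines account for the step. Plain phenyl or 4-fluorophenyl on the same oxygen would test how far the step depends on their number.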